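This account rests on a few compounds, and the source may have more. Where it says the series, first, only, none or still open, it means among the compounds named here.

Among the measured compounds shown here, in a functional assay on U-251 cells (Homo sapiens) for inhibition (on this read-out higher numbers stand for weaker inhibition of growth and lower numbers for stronger inhibition of growth), compound 3 `COc1ccc(-c2cn(-c3cccc(C(=O)/C=C/c4ccc(O)c(OC)c4)c3)c(=O)[nH]2)cc1` gives 3450 nM, which stands at the top of the three numbers measured so far. Compound 1 `COc1cc(/C=C/C(=O)c2cccc(-n3cc(-c4ccc(Cl)cc4)[nH]c3=O)c2)cc(OC)c1OC` gives 2120 nM in this assay, and compound 2 `COc1cc(/C=C/C(=O)c2cccc(-n3cc(-c4ccccc4)[nH]c3=O)c2)cc(OC)c1OC` gives 630 nM. The gap between compound 3 and compound 1 lies within the usual scatter, so those two cannot be ranked against each other, while the gap between compound 3 and compound 2 lies beyond it.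

Compound 4 `COc1ccc(-c2cn(-c3cccc(C(=O)/C=C/c4cc(OC)c(OC)c(OC)c4)c3)c(=O)[nH]2)cc1` has not yet been measured. It differs from compound 3 in one place: 3,4,5-trimethoxyphenyl in place of 4-hydroxy-3-methoxyphenyl on a double-bonded chain carbon bound to a double-bonded chain carbon. For the measured compounds named here, no measured step covers this exact exchange. Going by the values given here, the only step between measured compounds, a 3.4-fold lower number from compound 1 to compound 2 (0.53 log units; beyond the scatter), concerns a different part of the molecule and says nothing directly about the group on the chain.

What can be drawn on is that compound 1 and compound 2 already carry the 3,4,5-trimethoxyphenyl that enters in compound 4, and in this assay their numbers sit at or below that of compound 3. Compound 4 is therefore expected to land in a similar region, with an estimated step of a 2.9-fold lower number from compound 3 to compound 4 (0.46 log units; beyond the scatter), though the direction is uncertain. The estimate for compound 4 in this assay is 1200 nM, within a range from 400 nM to 4000 nM.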

Compound 4, concentration for 50% growth inhibition: 880 nM
Compound 4: the middle estimate sits 1.4-fold (0.13 log units) above what was measured; the range from low to high includes it.
By their numbers in this assay, from the lowest: compounds 2 and 4 (each within the scatter of the next); then compounds 1 and 3 (each within the scatter of the next).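

In this assay, among the compounds shown here, 3,4,5-trimethoxyphenyl in place of 4-hydroxy-3-methoxyphenyl on the chain gives a 3.9-fold lower number from compound 3 to compound 4 (0.59 log units; beyond the scatter) and so provides the first direct reading at this position: in this pair, the exchange goes with stronger inhibition of growth. With 3,4,5-trimethoxyphenyl held fixed on the chain, methoxy in place of hydrogen on an aromatic carbon gives a 1.4-fold higher number from compound 2 to compound 4 (0.15 log units; within the scatter) and leaves compound 2 and compound 4 unranked, while methoxy in place of chloro at that carbon gives a 2.4-fold lower number from compound 1 to compound 4 (0.38 log units; beyond the scatter) and marks a real separation in this single pair. No measurement at hand explains why any of these numbers move.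

The exchange on the chain removes the hydroxy group and adds methoxy groups in one move, so these compounds cannot show which part of it goes with the lower number. Also open, as far as these compounds go, is how the same core would read with a dimethylamino group or a carboxylic acid on the ring attached to the chain, and whether the same exchange on the chain would give a similar step with hydrogen or chloro in place of the methoxy on the other aromatic ring.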